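2-Chlorophenyl for 4-Methylphenyl: Cytotoxicity Expected Unchanged

The source may hold more compounds than are shown below. What is called first, only, known or untested is meant among the compounds shown, and "the series" means these compounds.

Compound 1, `O=c1[nH]cc(S(=O)(=O)Nc2ccccc2-c2cn(-c3ccccc3F)nn2)c(=O)[nH]1`: > 100000 nM
Compound 2, `O=c1[nH]cc(S(=O)(=O)Nc2ccccc2-c2cn(-c3cccc(Cl)c3)nn2)c(=O)[nH]1`: > 100000 nM
Compound 3, `Cc1ccc(-n2cc(-c3ccc(NS(=O)(=O)c4c[nH]c(=O)[nH]c4=O)cc3)nn2)cc1`: "not toxic" (no number reported)

All three compounds were examined in an ADME assay on GES1 cells (Homo sapiens) for cytotoxicity, read by MTT assay, with a stated time of 24 h; on this read-out higher numbers stand for lower toxicity in this test and lower numbers for higher toxicity in this test. Compound 1 reaches only a limit of the test, > 100000 nM, not a number. Compound 2 likewise reaches only a limit, > 100000 nM. Compound 3 has no number at all in this assay and is described simply as "not toxic" (no number reported). Within the data shown here, the one pair that differs in a single place gives a step that the two limits leave unreadable from compound 1 to compound 2, so nothing about the size of that change can be read. What the three share is summed up by the limit of > 100000 nM in this assay, at which 2 of the 3 values shown sit, and compound 3 stands with them, without any value that would set it apart.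

The next compound, compound 4, `O=c1[nH]cc(S(=O)(=O)Nc2ccc(-c3cn(-c4ccccc4Cl)nn3)cc2)c(=O)[nH]1`, differs from compound 3 by 2-chlorophenyl in place of 4-methylphenyl on an aromatic nitrogen. Among the measured compounds shown here, no measured step bears directly on this change, since the only step on record is unreadable, and every value so far sits at or beyond the upper edge of what this assay reports. Compound 4 is therefore expected to show no movement beyond the scatter in this assay and, most likely, to return another limit rather than a number. Compound 4 is estimated at 150000 nM, with a range of 50000 nM to 500000 nM.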

Compound 4, half-maximal cytotoxic concentration: 16400 nM
Estimate against measurement, compound 4: 9.1-fold (0.96 log units) above; the whole stated range lies above it.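

In this assay, among these compounds, compound 4 gives 16400 nM, but compound 3 carries only the words "not toxic", and no step from compound 3 to compound 4 can be read. The compounds shown leave open whether 2-chlorophenyl in place of 4-methylphenyl alone accounts for the number of compound 4, and nothing shown here explains that number.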